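A few compounds are considered here, and "the series" means these few. Any claim that something is new, unique, unknown or untested is made for them only; others in the source may bear on it.

Working notes on the series. In a physicochemical assay for solubility (a lower number here means a less soluble compound, a higher number a more soluble compound), compound 1 (`Cc1nc(C)c(COC(=O)NCC(=O)Oc2ccc(-c3cc(=O)c4c(O)c(O)c(O)cc4o3)cc2)nc1C`) gives 454 ug/mL, compound 2 (`Cc1nc(C)c(COC(=O)N[C@H](C)C(=O)Oc2ccc(-c3cc(=O)c4c(O)c(O)c(O)cc4o3)cc2)nc1C`) gives 799 ug/mL and compound 3 (`Cc1nc(C)c(COC(=O)N[C@H](CC(C)C)C(=O)Oc2ccc(-c3cc(=O)c4c(O)c(O)c(O)cc4o3)cc2)nc1C`) gives 221 ug/mL, the lowest of the three numbers. Compound 4 (`CC[C@H](C)[C@@H](NC(=O)OCc1nc(C)c(C)nc1C)C(=O)Oc1ccc(-c2cc(=O)c3c(O)c(O)c(O)cc3o2)cc1`) differs from compound 3 by sec-butyl in place of isobutyl on a saturated chain carbon bound to an amide-type nitrogen and a carbonyl carbon. Among the compounds with values here, the two have the same atoms, joined differently, and no measured step covers this swap directly. The nearest evidence is a 2.1-fold lower number from compound 1 to compound 3 (0.31 log units; beyond the scatter) and a 3.6-fold lower number from compound 2 to compound 3 (0.56 log units; beyond the scatter), both modest, while a 1.8-fold higher number from compound 1 to compound 2 (0.25 log units; within the scatter) stays within the scatter. No step beyond the scatter is therefore expected in this assay, and the estimated change is a 1.1-fold higher number from compound 3 to compound 4 (0.04 log units; within the scatter). Compound 4 is expected at 240 ug/mL, with an estimated range of 110 ug/mL to 480 ug/mL.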

Compound 4, solubility: 234 ug/mL
Estimate against measurement, compound 4: 1.0-fold (0.01 log units) above; measured number inside the range.
By their numbers in this assay, from the lowest: compounds 3, 4, 1 and 2 (each within the scatter of the next, the first and the last beyond it).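

In this assay, sec-butyl in place of isobutyl on this saturated chain carbon gives a 1.1-fold higher number from compound 3 to compound 4 (0.02 log units; within the scatter), so this assay does not separate these two branched groups of four carbons. Against the methyl compound the sec-butyl group gives a 3.4-fold lower number from compound 2 to compound 4 (0.53 log units; beyond the scatter), while against the hydrogen compound it gives a 1.9-fold lower number from compound 1 to compound 4 (0.29 log units; within the scatter). Nothing available bears on the reason for these steps.

From the compounds shown here alone, what an amine, a carboxylic acid or a longer unbranched chain on this carbon would do to the number remains open.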